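This account rests on a few compounds, and the source may have more. Where it says the series, first, only, none or still open, it means among the compounds named here.

Compound 1, `CCOC(=O)C1=C(C)NC(C(OCC)OCC)=C(C(=O)OCC)C1c1cccc([N+](=O)[O-])c1`: 615 nM
Compound 2, `CCOC(=O)C1=C(C)NC(C)=C(C(=O)OC=O)C1c1cccc([N+](=O)[O-])c1`: 13900 nM
Compound 3, `COC(=O)C1=C(C)NC(C)=C(C(=O)OCc2cc([N+](=O)[O-])cc([N+](=O)[O-])c2)C1c1cccc([N+](=O)[O-])c1`: 40 nM

Of the compounds shown here, three sharing one core have been measured in a functional assay on HEK293 cells for antagonist activity at Voltage-dependent L-type calcium channel subunit alpha-1D (Rattus norvegicus), read by FLIPR; on this read-out higher numbers stand for weaker inhibition and lower numbers for stronger inhibition. Compound 3 gives the lowest number of the three, and both gaps to the others lie beyond the scatter: compound 1 sits higher, and compound 2 higher still, making compound 3 the strongest inhibitor among the measured set. No pair of these compounds differs in a single place, so none of them shows directly how one change in the ester part moves the read-out.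

Compound 4, `COC(=O)C1=C(C)NC(C)=C(C(=O)OCCCOc2ccccc2)C1c1cccc([N+](=O)[O-])c1`, is the next compound to be tested. It differs from compound 3 by 2-phenoxyethyl in place of 3,5-dinitrophenyl on a saturated chain carbon bound to an oxygen next to a carbonyl group. Within the data shown here, with no single-change step among the measured compounds to lean on, the expectation rests on the position of compound 3 alone. The step of a 3.8-fold higher number from compound 3 to compound 4 (0.57 log units; beyond the scatter) is expected to go upward, toward weaker inhibition, by an amount somewhat beyond the scatter. Compound 4 is therefore estimated at 150 nM in this assay, with a range from 30 nM to 800 nM.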

Compound 4, half-maximal inhibitory concentration: 11 nM
For compound 4 the middle estimate is 14-fold (1.13 log units) above the measured one, and the stated range ends above it.
By their numbers in this assay, from the lowest: compound 4; then compound 3; then compound 1; then compound 2.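

In this assay, among these compounds, exchanging 3,5-dinitrophenyl for 2-phenoxyethyl gives the first single-change step in this set (a 3.6-fold lower number from compound 3 to compound 4 (0.56 log units; beyond the scatter)), a modest move toward stronger inhibition. This position therefore keeps strong inhibition without the nitro groups, even though the entering group has fewer heavy atoms and hydrogen-bond acceptors than the one it replaces. Nothing shown here accounts for the size or direction of this step.

Because the ring's substituents and the link to the ring change together, this one step cannot say which of them moves the read-out. It also leaves open how this position would respond to a piperidine amine in place of the phenoxy group, or to a longer chain.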